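Swapping dimethylamino for diethylamino on compound 3

This account rests on a few compounds, and the source may have more. Where it says the series, first, only, none or still open, it means among the compounds named here.

Values in an ADME assay (liver) for metabolic stability, with Liver microsome (Homo sapiens) as the target, read by LC-MS, using microsomes, tested at 1 uM (on this read-out lower numbers stand for a shorter-lived compound and higher numbers for a longer-lived compound), are these:
Compound 1 `CCN(CC)CCCN/C(=N\c1ccnc2cc(Cl)ccc12)c1cccnc1` gives 0.6 h
Compound 2 `CN(C)CCCN/C(=N\c1ccnc2cc(Cl)ccc12)c1ccc(Cl)cc1` gives 0.8 h
Compound 3 `CN(C)CCCN/C(=N\c1ccnc2cc(Cl)ccc12)c1ccccc1` gives > 1 h (a limit, not a number)

Compound 3 has no exact number: its > 1 h in this assay is a limit of the assay.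

Compound 4 `CCN(CC)CCCN/C(=N\c1ccnc2cc(Cl)ccc12)c1ccccc1` differs from compound 3 in one group, on a saturated chain carbon, three bonds along the chain from an amine nitrogen: diethylamino in place of dimethylamino on a saturated chain carbon, three bonds along the chain from an amine nitrogen and nothing else changes.

Among the compounds with values here, the one measured step, an at least 1.2-fold higher number from compound 2 to compound 3 (0.09 log units; that floor lies within the scatter) puts hydrogen in place of chloro on an aromatic carbon, a different change in a different place, so it gives little guidance here. Within the data shown here, no measured pair isolates the swap of dimethylamino for diethylamino. Compound 1 does carry diethylamino and gives 0.6 h but it also differs from compound 4 elsewhere, so it is only a loose guide. On that basis, a small fall in half-life is expected, probably not beyond the usual scatter. The expected change is an at least 1.2-fold lower number from compound 3 to compound 4 (0.09 log units; that floor lies within the scatter) and this is only an estimate. For compound 4 the estimated half-life is 0.8 h with an expected range from 0.4 h to 1.5 h in this assay and a limit instead of a number remains possible.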

Compound 4, half-life: 0.35 h
Beside the measured number, compound 4's estimate is 2.3-fold (0.36 log units) above it; measured number below the stated range.
By their numbers in this assay, from the lowest: compounds 4, 1 and 2 (each within the scatter of the next, the first and the last beyond it). At a limit, above all of these: compound 3.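

In this assay, within the data shown here, the step of an at least 2.8-fold lower number from compound 3 to compound 4 (0.45 log units; beyond the scatter) is the first measured pair that isolates the swap of dimethylamino for diethylamino on this saturated chain carbon, and in this one pair diethylamino goes with a shorter half-life. The value of compound 3 is a limit and not a number, so this step gives only a floor and its full size stays unknown: the limit of > 1 h in this assay, at which 1 of the 4 values shown sits.

The second new pair changes a different place, putting phenyl in place of pyridin-3-yl on a carbon with a double bond to nitrogen while diethylamino stays, and the step of a 1.7-fold lower number from compound 1 to compound 4 (0.23 log units; within the scatter) does not separate these two compounds.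

The compounds shown leave open whether a ring amine such as pyrrolidine or morpholine in the same place would track dimethylamino or diethylamino. They also do not tell whether the swap has the same result with the chloro group of compound 2 present, or why the half-life differs.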